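From fluoro to 4-methylpiperazin-1-yl in a cytotoxicity test

The source may report more compounds than this note shows. Statements on the series, on what has been measured and on what is new or still open speak of the compounds shown alone.

In an ADME assay on BEAS-2B cells (Homo sapiens) for cytotoxicity, read by MTT assay, with a stated time of 72 h (on this read-out lower numbers stand for stronger inhibition and higher numbers for weaker inhibition), compound 1 (`COc1ccc(Nc2cc(NC(=O)c3ccccc3)ncn2)cc1`) gives 18500 nM and compound 2 (`COc1ccc(OC)c(Nc2cc(Nc3ccc(F)cc3)ncn2)c1`) gives 18000 nM so compound 2 stands within the scatter of compound 1. Compound 3 (`COc1ccc(OC)c(Nc2cc(Nc3ccc(N4CCN(C)CC4)cc3)ncn2)c1`) has not yet been measured. It carries 4-methylpiperazin-1-yl in place of fluoro on an aromatic carbon of a six-membered aromatic ring of carbon only, para to a large group (4-methylpiperazin-1-yl in place of fluoro on an aromatic carbon). Within the data shown here, no measured pair of compounds differing in one place is available, so the data do not size this change. The expected step in this assay is a 2.6-fold lower number from compound 2 to compound 3 (0.41 log units; beyond the scatter) and it is estimated to point modestly toward stronger inhibition, although a result within the scatter remains possible. Compound 3 is expected at 7000 nM with an estimated range from 2000 nM to 25000 nM on present evidence.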

Compound 3, half-maximal inhibitory concentration: 18100 nM
Beside the measured number, compound 3's estimate is 2.6-fold (0.41 log units) below it; low and high end bracket the measured number.
By their numbers in this assay, from the lowest: compounds 2, 3 and 1 (each within the scatter of the next).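

In this assay, the exchange of fluoro for 4-methylpiperazin-1-yl gives a 1.0-fold higher number from compound 2 to compound 3 (0.00 log units; within the scatter), so the two compounds cannot be told apart on this read-out. Among these compounds, this is the only measured step at this place, on an aromatic carbon para to a large group, and it shows that a single fluorine atom and a far larger group with a six-membered non-aromatic ring give numbers within the scatter of each other. Nothing measured here offers an explanation for this result.

The compounds shown leave open whether this holds for other kinds of group at the same place, such as a carboxylic acid, a simple dimethylamino group or a longer chain ending in an amine. They also leave open whether the same exchange would give a similar result on a core with different groups elsewhere.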